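Growing the Alkyl Chain from Ethyl to Isobutyl

This account rests on a few compounds, and the source may have more. Where it says the series, first, only, none or still open, it means among the compounds named here.

Of the compounds shown here, three built on one shared core have been tested in a functional assay on CHO-K1 cells for agonist activity at Glucose-dependent insulinotropic receptor (Homo sapiens), read by cAMP accumulation and immunoassay, with a stated time of 1 h; a lower number here means that less compound is needed, a higher number that more compound is needed for the effect. Compound 1 `COC(=O)N1CCC(Oc2ncnc(Oc3ccc(/C=C4\SC(=O)NC4=O)cc3)c2C)CC1` gives 1410 nM. Compound 2 `CCOC(=O)N1CCC(Oc2ncnc(Oc3ccc(/C=C4\SC(=O)NC4=O)cc3)c2C)CC1` gives 157 nM, so that a 9.0-fold lower number from compound 1 to compound 2 (0.95 log units; beyond the scatter). Compound 3 `CCOC(=O)N1CCC(Oc2cc(Oc3ccc(/C=C4\SC(=O)NC4=O)cc3)ncn2)CC1` gives 790 nM, where a 5.0-fold higher number from compound 2 to compound 3 (0.70 log units; beyond the scatter). Compound 3 therefore sits within the usual scatter of compound 1 and clearly needs more compound than compound 2.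

Compound 4 `CC(C)COC(=O)N1CCC(Oc2cc(Oc3ccc(/C=C4\SC(=O)NC4=O)cc3)ncn2)CC1` has not yet been measured. It differs from compound 3 by isopropyl in place of methyl on a saturated chain carbon bound to an oxygen next to a carbonyl group. Within the data shown here, the one measured step at this same place is the change from compound 1 to compound 2, where a 9.0-fold lower number from compound 1 to compound 2 (0.95 log units; beyond the scatter); that step added a single carbon, whereas the present change adds a branched group. Growth at this position has so far lowered the number, so a further drop is expected, though a larger group need not repeat the full size of that gain. The expected step is a 2.6-fold lower number from compound 3 to compound 4 (0.42 log units; beyond the scatter). Compound 4 is estimated to give 300 nM in this assay, within a range from 80 nM to 1200 nM.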

Compound 4, half-maximal effective concentration: 745 nM
Compound 4: middle estimate off by 2.5-fold (0.40 log units), on the low side; low and high end bracket the measured number.
By their numbers in this assay, from the lowest: compound 2; then compounds 4, 3 and 1 (each within the scatter of the next).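

Going from ethoxycarbonyl to isobutoxycarbonyl in this assay gives a 1.1-fold lower number from compound 3 to compound 4 (0.03 log units; within the scatter) and so makes no readable difference. Compound 4 therefore goes against the drop seen earlier at this same place, a 9.0-fold lower number from compound 1 to compound 2 (0.95 log units; beyond the scatter) and shows that adding carbon here does not always lower the number, although that earlier step was from methyl to ethyl on a core with methyl on an aromatic carbon, where compounds 3 and 4 have hydrogen. No supporting measurement bears on why the two steps differ.

Still open, on these data alone, is whether isobutyl would leave the number unchanged on the core of compound 2, which carries that aromatic methyl. Also open, as far as these compounds go, is how a straight propyl or butyl chain would compare with isobutyl at this place.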